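A few compounds are considered here, and "the series" means these few. Any claim that something is new, unique, unknown or untested is made for them only; others in the source may bear on it.

Two compounds of this series already have a number in a functional assay on MGC-803 cells (Homo sapiens) for inhibition, read by MTT assay, with a stated time of 72 h; on this read-out higher numbers stand for weaker inhibition and lower numbers for stronger inhibition. Compound 1 `C#CCSc1nc(Nc2ccc(OC)cc2)c(C#N)c(-c2ccccc2)n1` gives 28400 nM in this assay. Compound 2 `N#Cc1c(Nc2ccc(Cl)cc2)nc(SCc2cn(Cc3ccccc3Cl)nn2)nc1-c1ccccc1` gives 5850 nM in this assay, the lower of the two numbers, and the gap between compound 2 and compound 1 lies beyond the scatter of repeated measurements. Compound 3 `N#Cc1c(Nc2ccccc2F)nc(SCc2cn(Cc3ccccc3Cl)nn2)nc1-c1ccccc1` has not yet been measured in this assay. It differs from compound 2 in one place: 2-fluorophenyl in place of 4-chlorophenyl on a nitrogen on an aromatic ring. Among the compounds with values here, no pair of measured compounds shows the effect of such an exchange, and the two measured compounds differ from each other in more than this one place, so the data give no direct guide to how the number should move. The expectation for compound 3 is therefore a small step from compound 2, most likely within the scatter or at most a modest weakening, a 1.4-fold higher number from compound 2 to compound 3 (0.14 log units; within the scatter). In this assay compound 3 is expected to give about 8000 nM, with a range from 3000 nM to 25000 nM.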

Compound 3, half-maximal inhibitory concentration: 7580 nM
Compound 3: middle estimate off by 1.1-fold (0.02 log units), on the high side; low and high end bracket the measured number.
By their numbers in this assay, from the lowest: compounds 2 and 3 (each within the scatter of the next); then compound 1.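

In this assay, within the data shown here, the exchange of 4-chlorophenyl for 2-fluorophenyl on a nitrogen on an aromatic ring gives a 1.3-fold higher number from compound 2 to compound 3 (0.11 log units; within the scatter) and is the first step that can be read at a single place. It shows that, with the rest of compound 2 held constant, this assay does not tell these two halogen-bearing phenyl groups apart, although the halogen and its place on the ring both change. Nothing available speaks to why the two groups read alike.

The step changes the halogen and its place on the ring together, so the compounds shown cannot say whether either change alone would leave the number as flat, or whether the two changes happen to offset each other. They also leave open whether this position stays as undemanding with a quite different group on the phenyl ring, such as an amine, a carboxylic acid or a longer chain, and whether any such group could bring the number below that of compound 2 by more than the usual scatter.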